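Chloro to iodo on the indole of compound 2

This account rests on a few compounds, and the source may have more. Where it says the series, first, only, none or still open, it means among the compounds named here.

In an assay on isolated protein for inhibition of Calpain-1 catalytic subunit (Homo sapiens), read by fluorescence, with a stated time of 60 min, tested at 1 uM (on this read-out lower numbers stand for less inhibition and higher numbers for more inhibition at the one concentration tested (going by the name of the read-out)), compound 2 `COCCN/C(=C1/N=CN(CCOC)C1=O)c1[nH]c2ccccc2c1Cl` gives 71.9%, the higher of the two measured numbers. The other measured compound, compound 1 `O=C1/C(=C(\NCc2ccccc2)c2cc3ccccc3[nH]2)N=CN1Cc1ccccc1`, gives 28.2% in this assay, a gap that lies beyond the usual scatter. The next compound, compound 3 `COCCN/C(=C1/N=CN(CCOC)C1=O)c1[nH]c2ccccc2c1I`, differs from compound 2 by iodo in place of chloro on an aromatic carbon. Among the compounds with values here, no step between measured compounds that differ in a single place has been recorded, so the effect of this change is unknown. On this basis compound 3 is expected to stay close to compound 2 in this assay, a step of a number 2.1 percentage points higher from compound 2 to compound 3 (within the scatter) within the scatter, and its estimated inhibition is 74%, ranging from 55% to 90%.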

Compound 3, a percentage reported as inhibition, at one concentration (the size of the read-out at that concentration, not a potency): 76.8%
Compound 3: the middle estimate sits 2.8 percentage points below what was measured, within the range that was stated.
By their numbers in this assay, from the lowest: compound 1; then compounds 2 and 3 (each within the scatter of the next).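

In this assay, within the data shown here, the first step in a single place, a number 4.9 percentage points higher from compound 2 to compound 3 (within the scatter), shows that iodo in place of chloro on this aromatic carbon leaves the inhibition within the scatter. At this position, two ring bonds from the ring nitrogen, the two halogens cannot be told apart at the one concentration tested. Nothing measured here accounts for this result. The compounds shown leave open whether a plain hydrogen, an amine or a nitrile on this carbon would keep the inhibition at this level.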